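A few compounds are considered here, and "the series" means these few. Any claim that something is new, unique, unknown or untested is made for them only; others in the source may bear on it.

Compound 1 `CCCNC(=O)/N=C(\N)NCCCc1sc(N)nc1C` is the reference point. Among the compounds with values here, in an assay on membranes from Sf9 cells for displacement of a labelled ligand from histamine H2 receptor (Homo sapiens), read by scintillation counting, with a stated time of 60 min (a higher number here means a weaker inhibitor, a lower number a stronger inhibitor), compound 1 gives 105 nM, the higher of the two numbers measured so far. Compound 2 `CCC(NC(=O)/N=C(\N)NCCCc1sc(N)nc1C)c1ccccc1` carries a phenyl on the chain and gives 63.1 nM in this assay, a step of a 1.7-fold lower number from compound 1 to compound 2 (0.22 log units; within the scatter). Compound 3 `Cc1nc(N)sc1CCCN/C(N)=N/C(=O)NCC(C)CCCc1ccccc1` differs from compound 1 by 3-phenylpropyl in place of hydrogen on a saturated chain carbon bound to two saturated chain carbons, placed on a saturated chain carbon bound to two saturated chain carbons. Within the data shown here, the only step that bears on this, from compound 1 to compound 2, stayed within the scatter, so any change in this assay is expected to be small. Compound 3 is therefore estimated at 75 nM, with a range from 25 nM to 220 nM, a step of a 1.4-fold lower number from compound 1 to compound 3 (0.15 log units; within the scatter).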

Compound 3, inhibition constant: 60.3 nM
Compound 3: the middle estimate sits 1.2-fold (0.09 log units) above what was measured; the range from low to high includes it.
By their numbers in this assay, from the lowest: compounds 3, 2 and 1 (each within the scatter of the next).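

In this assay, placing 3-phenylpropyl on a saturated chain carbon bound to two saturated chain carbons gives a 1.7-fold lower number from compound 1 to compound 3 (0.24 log units; within the scatter) and so no readable change. This shows that a second site on the chain of compound 1 accepts a group of 9 heavy atoms, including an aromatic ring, while the number stays within the scatter. No measurement here explains this result. Going by these compounds, whether an amine or a carboxylic acid in place of 3-phenylpropyl would also leave the number within the scatter stays open.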